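The source may report more compounds than this note shows. Statements on the series, on what has been measured and on what is new or still open speak of the compounds shown alone.

Three compounds have been measured in a functional assay on MIA PaCa-2 cells (Homo sapiens) for inhibition, read by MTT assay, with a stated time of 48 h, tested at 10 uM; on this read-out higher numbers stand for more inhibition of growth at the one concentration tested and lower numbers for less inhibition of growth:

Compound 1 `O=C(/C=C/c1ccc(OCc2cn(Cc3ccccc3F)nn2)cc1)c1ccc(Br)cc1`: 28%
Compound 2 `O=C(/C=C/c1ccc(OCc2cn(Cc3cccc(F)c3)nn2)cc1)c1ccc(Br)cc1`: 34%
Compound 3 `COc1ccc(C(=O)/C=C/c2ccc(OCc3cn(Cc4ccccc4F)nn3)cc2)cc1`: 19%

Compound 1 and compound 2 share a core and differ in one place: 3-fluorophenyl in place of 2-fluorophenyl on a saturated chain carbon bound to an aromatic nitrogen. This change is accompanied by a step of a number 6 percentage points higher from compound 1 to compound 2 (within the scatter), which is too small to be told apart from the ordinary spread of repeated measurements, so the two values are best read as alike.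

Compound 3 carries a different core, and the difference from the core of compound 1 is methoxy in place of bromo on an aromatic carbon. Going from compound 1 to compound 3 the value moved by a number 9 percentage points lower from compound 1 to compound 3 (within the scatter), again a step inside the usual spread.

Compound 4 `COc1ccc(C(=O)/C=C/c2ccc(OCc3cn(Cc4cccc(F)c4)nn3)cc2)cc1` has not yet been measured. It stands to compound 3 exactly as compound 2 stands to compound 1: 3-fluorophenyl in place of 2-fluorophenyl on a saturated chain carbon bound to an aromatic nitrogen. Both changes sit in the same place, described in the same words, so this is the same change made on a second core.

Because the earlier instance of this change gave only a number 6 percentage points higher from compound 1 to compound 2 (within the scatter), compound 4 is expected to lie close to compound 3, and the step is estimated at a number 6 percentage points higher from compound 3 to compound 4 (within the scatter). With that in mind, the value expected for compound 4 in this assay is 25%, with a likely range from 10% to 40%.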

Compound 4, percent growth inhibition at one concentration: 48%
Beside the measured number, compound 4's estimate is 23 percentage points below it, and the stated range ends below it.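

Swapping 2-fluorophenyl for 3-fluorophenyl on the core of compound 3 gave a number 29 percentage points higher from compound 3 to compound 4 (beyond the scatter) in this assay, so the size of this step did not carry over from the core of compound 1: the same change on two cores in this assay, a number 6 percentage points higher (within the scatter) from compound 1 to compound 2 and a number 29 percentage points higher (beyond the scatter) from compound 3 to compound 4, 23 percentage points apart, beyond the scatter of two such steps

Read along the other edge of the same four compounds, methoxy in place of bromo gave a number 14 percentage points higher from compound 2 to compound 4 (beyond the scatter), so the outcome of that change also differs with the fluorophenyl group present: the same change on two cores in this assay, a number 9 percentage points lower (within the scatter) from compound 1 to compound 3 and a number 14 percentage points higher (beyond the scatter) from compound 2 to compound 4, 23 percentage points apart, beyond the scatter of two such steps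

This shows that, within these four compounds, neither change has a fixed size that can simply be transferred from one core to the other, but it rests on a single set of four compounds at one concentration, so it does not show why the steps differ or that the same mismatch would appear on any further core.

On these data alone, it remains open whether a plain phenyl or a chlorophenyl group on the saturated chain carbon would follow compound 2 and compound 4 or behave differently. As far as these compounds go, it is also open whether a dimethylamino group or a chlorine in place of methoxy or bromo would show the same dependence on the fluorophenyl group.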